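The source may report more compounds than this note shows. Statements on the series, on what has been measured and on what is new or still open speak of the compounds shown alone.

In a functional assay on K562 cells (Homo sapiens) for inhibition, with a stated time of 72 h (a higher number here means a weaker inhibitor, a lower number a stronger inhibitor), compound 1 `NC1CCC(Nc2nc(NCc3ccc(-c4ccccc4)cc3)c3ncn(C4CCCC4)c3n2)CC1` gives 530 nM, compound 2 `COc1ccccc1-c1ccc(CNc2nc(NC3CCC(N)CC3)nc3c2ncn3C2CCCC2)cc1` gives 347 nM and compound 3 `NC1CCC(Nc2nc(NCc3ccc(-c4cccc(F)c4)cc3)c3ncn(C4CCCC4)c3n2)CC1` gives 290 nM. Compound 3 therefore stands within the scatter of both other compounds. Compound 4 `NC1CCC(Nc2nc(NCc3ccc(-n4cccn4)cc3)c3ncn(C4CCCC4)c3n2)CC1` has not yet been measured, and it carries 1H-pyrazol-1-yl in place of 3-fluorophenyl on an aromatic carbon. The nearest evidence is a 1.2-fold lower number from compound 2 to compound 3 (0.08 log units; within the scatter), an exchange of one substituted phenyl for another at this place. The additions to the phenyl ring are small as well, with a 1.5-fold lower number from compound 1 to compound 2 (0.18 log units; within the scatter) and a 1.8-fold lower number from compound 1 to compound 3 (0.26 log units; within the scatter). None of these steps replaces the phenyl ring with a five-membered ring, so the data offer only a weak guide and the range must stay wide. On this evidence, no step beyond the scatter is expected in this assay, though a slightly higher number is thought more likely than a lower one. The expected change is a 1.6-fold higher number from compound 3 to compound 4 (0.19 log units; within the scatter). For compound 4 the estimated value is 450 nM, with an expected range from 170 nM to 1200 nM.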

Compound 4, half-maximal inhibitory concentration: 119 nM
Estimate against measurement, compound 4: 3.8-fold (0.58 log units) above, outside the stated range (below it).
By their numbers in this assay, from the lowest: compound 4; then compounds 3, 2 and 1 (each within the scatter of the next).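

At this place, on an aromatic carbon of a six-membered aromatic ring of carbon only, para to a large group, changes to the phenyl group had stayed within the scatter in this assay, whereas the exchange for a five-membered aromatic ring with 2 hetero atoms goes beyond it. The step is a 2.4-fold lower number from compound 3 to compound 4 (0.39 log units; beyond the scatter), and it is of similar size against the other two compounds, at a 2.9-fold lower number from compound 2 to compound 4 (0.46 log units; beyond the scatter) and a 4.5-fold lower number from compound 1 to compound 4 (0.65 log units; beyond the scatter), so compound 4 is the strongest inhibitor of the four in this assay. The position therefore does not require a six-membered carbon ring, and 1H-pyrazol-1-yl, with fewer heavy atoms than 3-fluorophenyl, is tolerated here; no supporting measurement explains the gain.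

The compounds shown do not separate ring size from the presence of the ring nitrogens. A 2-thienyl group, a 3-pyridyl group or a 1H-imidazol-1-yl group at this place would bear on that question.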